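A few compounds are considered here, and "the series" means these few. Any claim that something is new, unique, unknown or untested is made for them only; others in the source may bear on it.

Measured so far in an assay on isolated protein for inhibition of histone deacetylase 8 (Homo sapiens); on this read-out higher numbers stand for weaker inhibition and lower numbers for stronger inhibition:
compound 1 `Cc1ccc(C(=O)c2ccc3c(ccn3Cc3ccc(C(=O)NO)cc3)c2)cc1` gives 1490 nM
compound 2 `COc1ccc(C(=O)c2ccc3c(ccn3Cc3ccc(/C=C/C(=O)NO)cc3)c2)cc1` gives 2810 nM
compound 3 `COc1cccc(C(=O)c2ccc3c(ccn3Cc3ccc(C(=O)NO)cc3)c2)c1` gives 1120 nM

Compound 3 stands with compound 1 inside the usual scatter: the exchange of one aryl group on the carbonyl carbon, a 1.3-fold lower number from compound 1 to compound 3 (0.12 log units; within the scatter), did not move the read-out in a way that can be told from repeat noise. Compound 2, which differs from the others in the part carrying the hydroxamic acid, gives 2810 nM, and that gap to compound 3 lies beyond the scatter.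

Compound 4 `O=C(NO)c1ccc(Cn2ccc3cc(C(=O)c4ccc(F)cc4)ccc32)cc1` is the next point on the same carbonyl carbon. The change from compound 3 is 4-fluorophenyl in place of 3-methoxyphenyl on a carbonyl carbon. Among the measured compounds shown here, the only measured step that speaks to it is the same kind of aryl exchange at that carbon, a 1.3-fold lower number from compound 1 to compound 3 (0.12 log units; within the scatter), which stayed within the scatter. For the measured compounds named here, compound 1 carries 4-methylphenyl and compound 4 carries 4-fluorophenyl, but no step between those two has been measured, so only the value of compound 1 can be set beside the coming result. Nothing in the three numbers argues for a movement beyond the scatter, so the expected step is a 1.2-fold higher number from compound 3 to compound 4 (0.06 log units; within the scatter). Compound 4 is therefore estimated at 1300 nM in this assay, with an expected range of 600 nM to 2900 nM.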

Compound 4, half-maximal inhibitory concentration: 1240 nM
Compound 4: middle estimate off by 1.0-fold (0.02 log units), on the high side, and the stated range covers the measured number.
By their numbers in this assay, from the lowest: compounds 3, 4, 1 and 2 (each within the scatter of the next, the first and the last beyond it).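

In this assay, the exchange at the carbonyl carbon now covers a change of substitution place and substituent together, 4-fluorophenyl in place of 3-methoxyphenyl (a 1.1-fold higher number from compound 3 to compound 4 (0.04 log units; within the scatter)), and a single exchange on the aromatic ring, fluoro in place of methyl on an aromatic carbon (a 1.2-fold lower number from compound 1 to compound 4 (0.08 log units; within the scatter)). Both steps stay within the scatter, so compounds 1, 3 and 4 form a flat set at this carbon, even though the entering 4-fluorophenyl carries no hydrogen-bond acceptor and the leaving 3-methoxyphenyl carries one. No measurement at hand offers an explanation for this flatness.

All three aryl groups in this flat set are uncharged, so the compounds shown leave open whether an amine or a carboxylic acid on that ring, or a saturated ring such as cyclohexyl in place of the aryl group, would give a step beyond the scatter. On these data alone, compound 2 differs from each of the others in more than one place, so the effect of its altered part carrying the hydroxamic acid also remains open.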